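The source may hold more compounds than are shown below. What is called first, only, known or untested is meant among the compounds shown, and "the series" means these compounds.

Measured so far in a functional assay on PC-3 cells (Homo sapiens) for inhibition, read by MTT assay, with a stated time of 72 h; on this read-out higher numbers stand for weaker inhibition and lower numbers for stronger inhibition:

compound 1 `CC(C)(C)OC(=O)N1CCN(C(=S)SCc2cn(Cc3ccc(Cl)cc3)nn2)CC1`; compound 1 gives > 128000 nM, which is a limit of the assay and not a number.
compound 2 `COc1ccc(-n2cc(CSC(=S)N3CCN(C(=O)OC(C)(C)C)CC3)nn2)cc1`; compound 2 gives > 128000 nM, again only a limit.
compound 3 `Cc1ccc(Cn2cc(CSC(=S)N3CCN(C(=O)OC(C)(C)C)CC3)nn2)cc1`; compound 3 gives 17300 nM.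

For the measured compounds named here, compound 3 thus stands as the only numbered value; the other two sit at the limit of > 128000 nM in this assay, at which 2 of the 3 values shown sit. The step of an at least 7.3-fold lower number from compound 1 to compound 3 (0.86 log units; beyond the scatter) is the one that bears directly on the next compound, since it swaps chloro for methyl on the aromatic carbon of the benzyl group. The step of an at least 7.3-fold lower number from compound 2 to compound 3 (0.86 log units; beyond the scatter) exchanges the whole group on the aromatic nitrogen and is less direct. The step that the two limits leave unreadable from compound 1 to compound 2 cannot be read because both of its ends sit at the limit of > 128000 nM in this assay, at which 2 of the 3 values shown sit.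

Compound 4 `CC(C)(C)OC(=O)N1CCN(C(=S)SCc2cn(Cc3ccc(Cl)c(Cl)c3)nn2)CC1` carries 3,4-dichlorophenyl in place of 4-methylphenyl on a saturated chain carbon bound to an aromatic nitrogen. This returns the benzyl group to chloro substitution, now as 3,4-dichlorophenyl, and so undoes the change measured in an at least 7.3-fold lower number from compound 1 to compound 3 (0.86 log units; beyond the scatter); the number is therefore expected to move back up toward the limit, by a 4.0-fold higher number from compound 3 to compound 4 (0.61 log units; beyond the scatter). For compound 4 the estimate in this assay is 70000 nM, in the range 20000 nM to 200000 nM, with a real chance that only a limit is returned.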

Compound 4, half-maximal inhibitory concentration: > 128000 nM
Compound 4 gave a limit, no number; the forecaster's own chance of this, stated with the estimate: 45%; middle value at least 1.8-fold (0.26 log units) away from the limit.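

In this assay the change to 3,4-dichlorophenyl on a saturated chain carbon bound to an aromatic nitrogen gives an at least 7.3-fold higher number from compound 3 to compound 4 (0.86 log units; beyond the scatter) and so removes the numbered value of compound 3. With compound 1 and compound 4, two chloro-bearing benzyl groups now end at a limit, while 4-methylbenzyl in compound 3 is the only benzyl group shown that returns a number; no benzyl compound shown goes against this. The steps among compound 1, compound 2 and compound 4 cannot be read because both ends of each sit at a limit: the limit of > 128000 nM in this assay, at which 3 of the 4 values shown sit.

Going by these compounds, how far compound 4 lies from compound 3 stays open, since only a lower bound on that step is available. Also open, on these data alone, is whether 4-ethylbenzyl, unsubstituted benzyl or a benzyl group carrying an amine or a carboxylic acid would return a number at this place.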